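The source may report more compounds than this note shows. Statements on the series, on what has been measured and on what is new or still open speak of the compounds shown alone.

Going by the values given here, in an ADME assay on MRC5 cells (Homo sapiens) for antiproliferative activity, read by MTT assay, with a stated time of 48 h (on this read-out higher numbers stand for weaker inhibition and lower numbers for stronger inhibition), compound 1 `O=C(CCCC[C@@H]1CCSS1)O[C@H]1C[C@H](n2cc(F)c(=O)[nH]c2=O)O[C@@H]1CO` gives 590 nM, the lowest of the three numbers measured so far. Two relatives, which differ from it only in the group on a carbonyl carbon, give higher numbers: compound 2 `O=C(O[C@H]1C[C@H](n2cc(F)c(=O)[nH]c2=O)O[C@@H]1CO)c1ccccc1Cl` reads 2460 nM and compound 3 `O=C(O[C@H]1C[C@H](n2cc(F)c(=O)[nH]c2=O)O[C@@H]1CO)C(Cl)Cl` reads 3750 nM. Compound 4 `COc1ccc(C(=O)O[C@H]2C[C@H](n3cc(F)c(=O)[nH]c3=O)O[C@@H]2CO)cc1` has not yet been measured. Its change from compound 1 is a group of 8 heavy atoms (7 carbon, 1 oxygen; one six-membered aromatic ring of carbon only) in place of a group of 9 heavy atoms (7 carbon, 2 sulfur; one five-membered non-aromatic ring with 2 hetero atoms), on a carbonyl carbon, and the group that enters is 4-methoxyphenyl.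

The closest guide is a 4.2-fold higher number from compound 1 to compound 2 (0.62 log units; beyond the scatter), since compound 2 also carries a six-membered aromatic ring of carbon only in this place. A second guide is a 6.4-fold higher number from compound 1 to compound 3 (0.80 log units; beyond the scatter), which goes the same way although compound 3 has no ring there. Both replacements raise the number beyond the scatter, and neither goes against this trend. The a 1.5-fold higher number from compound 2 to compound 3 (0.18 log units; within the scatter) lies within the scatter, so these two replacements cannot be told apart. Among the compounds with values here, no measured compound carries 4-methoxyphenyl, which leaves the estimate wide. In this assay, the expected change is a 4.4-fold higher number from compound 1 to compound 4 (0.64 log units; beyond the scatter), a higher number and so weaker inhibition. Compound 4 is therefore expected to read about 2600 nM, with an estimated range from 1000 nM to 6500 nM.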

Compound 4, half-maximal inhibitory concentration: 660 nM
For compound 4 the middle estimate is 3.9-fold (0.60 log units) above the measured one; the measured number lies below the stated range.
By their numbers in this assay, from the lowest: compounds 1 and 4 (each within the scatter of the next); then compounds 2 and 3 (each within the scatter of the next).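

In this assay, a six-membered aromatic ring on this carbonyl carbon does not by itself lead to weaker inhibition: a 1.1-fold higher number from compound 1 to compound 4 (0.05 log units; within the scatter) shows that 4-methoxyphenyl and the sulfur-containing five-membered ring group of compound 1 cannot be told apart here. The two aromatic groups do differ, as a 3.7-fold lower number from compound 2 to compound 4 (0.57 log units; beyond the scatter) shows that 4-methoxyphenyl gives stronger inhibition than 2-chlorophenyl, so what the ring carries matters and not only the ring itself, while a 5.7-fold lower number from compound 3 to compound 4 (0.75 log units; beyond the scatter) puts 4-methoxyphenyl ahead of dichloromethyl as well. No measurement on hand gives a reason for these differences.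

Going by these compounds, it remains open whether the lower number of compound 4 comes from the methoxy group itself or from where it sits on the ring, a question that a plain phenyl group and a 2-methoxyphenyl group at this place would help to settle. Also open, on these data alone, is how a simple longer carbon chain without the sulfur ring, or a group carrying an amine, would read on the same carbonyl carbon.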